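Notes on a thyroid hormone receptor beta series

This account rests on a few compounds, and the source may have more. Where it says the series, first, only, none or still open, it means among the compounds named here.

Measured so far in an assay on isolated protein for inhibition of thyroid hormone receptor beta (Homo sapiens), read by fluorescence, with a stated time of 30 min; on this read-out higher numbers stand for weaker inhibition and lower numbers for stronger inhibition:
compound 1 `O=C(NCc1cccc(Cl)c1)c1ccc2cn(CCn3cccn3)nc2c1` gives 173 nM
compound 2 `COc1cc(C(=O)NCc2cccc(Cl)c2)cc2nn(CCn3cccn3)cc12` gives 464 nM
compound 3 `COc1cc(C(=O)N2CCCC2)cc2nc(NCc3cccc(Cl)c3)oc12` gives 180 nM

Compound 3 sits second highest of the three numbers. Its number and that of compound 1 lie within the scatter of each other, so no order between them is claimed; the gap to compound 2 is beyond the scatter.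

Going by the values given here, the only step measured within one scaffold is a 2.7-fold higher number from compound 1 to compound 2 (0.43 log units; beyond the scatter), a methoxy in place of hydrogen on an aromatic carbon. It does not touch the amide end of the molecule and so says nothing about the step now in question.

Compound 4 `CCC1CC(O)C(C)CN1C(=O)c1cc(OC)c2oc(NCc3cccc(Cl)c3)nc2c1` differs from compound 3 in one place: 2-ethyl-4-hydroxy-5-methylpiperidin-1-yl in place of pyrrolidin-1-yl on a carbonyl carbon. Among the compounds with values here, no measured pair shows what a change of the amine part of the carbonyl does in this assay, so the expectation rests on compound 3 alone and carries a wide range. No step beyond the scatter is expected in either direction. Compound 4 is expected to give 150 nM, within 40 nM to 600 nM. The expected step is a 1.2-fold lower number from compound 3 to compound 4 (0.08 log units; within the scatter).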

Compound 4, half-maximal inhibitory concentration: 13 nM
Beside the measured number, compound 4's estimate is 12-fold (1.06 log units) above it; measured number below the stated range.
By their numbers in this assay, from the lowest: compound 4; then compounds 1 and 3 (each within the scatter of the next); then compound 2.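

Going by these compounds alone, the amine part of the carbonyl proves to be a sensitive position in this assay, the first evidence on this point: the step is a 14-fold lower number from compound 3 to compound 4 (1.14 log units; beyond the scatter), with 2-ethyl-4-hydroxy-5-methylpiperidin-1-yl in place of pyrrolidin-1-yl on a carbonyl carbon. This single replacement swaps a five-membered ring for a six-membered one, raises the count of heavy atoms of the group, and adds a hydrogen-bond donor and acceptor, so a larger, substituted amine is tolerated here and goes with a much lower number. Nothing available accounts for the size of this step.

The compounds shown do not separate the contributions of the ethyl, hydroxy and methyl groups or of the ring size. As far as these compounds go, whether plain piperidin-1-yl, 4-hydroxypiperidin-1-yl or a morpholine would keep the low number remains open, as does whether the new amine would have the same effect on the core of compound 2.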